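Lengthening the hydroxycarbamoyl chain: compound 2 to compound 3

This account rests on a few compounds, and the source may have more. Where it says the series, first, only, none or still open, it means among the compounds named here.

Measured in a functional assay on MDA-MB-231 cells (Homo sapiens) for antiproliferative activity, read by MTT assay, with a stated time of 72 h (a higher number here means a weaker inhibitor, a lower number a stronger inhibitor), so far:
compound 1 `O=C(CCCn1cc(-c2ncnc3[nH]ccc23)cn1)NO` gives > 100000 nM
compound 2 `O=C(CCCCCCCn1cc(-c2ncnc3[nH]ccc23)cn1)NO` gives 12900 nM

The entry for compound 1 is a limit and not a number. Within the data shown here, compound 2 therefore holds the only actual number so far, at 12900 nM.

Compound 3 `O=C(CCCCCCCCCCn1cc(-c2ncnc3[nH]ccc23)cn1)NO` is not yet measured. The change from compound 2 is 3-(hydroxycarbamoyl)propyl in place of hydroxycarbamoyl on a saturated chain carbon, seven bonds along the chain from an aromatic nitrogen.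

Among the measured compounds shown here, the one measured step that bears on this also lengthens the chain, and it is an at least 7.7-fold lower number from compound 1 to compound 2 (0.88 log units; beyond the scatter). Its size is only a bound, set by the limit of > 100000 nM in this assay, at which 1 of the 2 values shown sits. A single step cannot show how far the trend continues, so only a slight further fall in this assay is expected, if any. The expected step is a 1.4-fold lower number from compound 2 to compound 3 (0.16 log units; within the scatter). The estimate for compound 3 is 9000 nM, with a range of 2500 nM to 32000 nM.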

Compound 3, half-maximal inhibitory concentration: 12900 nM
Compound 3: middle estimate off by 1.4-fold (0.16 log units), on the low side, and the stated range covers the measured number.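

In this assay, moving to 3-(hydroxycarbamoyl)propyl in place of hydroxycarbamoyl, seven bonds along the chain from an aromatic nitrogen, gives no change at the digits printed from compound 2 to compound 3 (within the scatter). Among these compounds, the fall seen on the earlier lengthening, an at least 7.7-fold lower number from compound 1 to compound 2 (0.88 log units; beyond the scatter), therefore does not carry on at this position, and compound 2 and compound 3 form the first pair with two actual numbers. Compound 1 is a limit and not a number, so the earlier step has no exact size: the limit of > 100000 nM in this assay, at which 1 of the 3 values shown sits.

The compounds shown leave open whether a longer chain than that of compound 3 would change the number. Also open, as far as these compounds go, is whether a carboxylic acid in place of hydroxycarbamoyl on the same chain would keep the activity seen with compound 2 and compound 3.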